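Swapping Methoxy for Chloro in a Cytotoxicity Series

The source may report more compounds than this note shows. Statements on the series, on what has been measured and on what is new or still open speak of the compounds shown alone.

Compound 1 `COc1cc(NC(=O)c2cccc(C(F)(F)F)c2)ccc1NS(C)(=O)=O`: in an ADME assay on HEK293 cells (Homo sapiens) for cytotoxicity, read by MTT assay, with a stated time of 48 h (on this read-out higher numbers stand for weaker inhibition and lower numbers for stronger inhibition), compound 1 reaches only the limit > 250000 nM.
Compound 2 `COc1cc(NC(=O)c2cc(C(F)(F)F)cc(C(F)(F)F)c2)ccc1NS(C)(=O)=O`: in this assay compound 2 gives 42000 nM.
Compound 3 `CCS(=O)(=O)Nc1ccc(NC(=O)c2cc(C(F)(F)F)cc(C(F)(F)F)c2)cc1OC`: in this assay compound 3 reaches only the limit > 250000 nM.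

Going by the values given here, compound 2 thus stands as the only true number among the three results; the other two are limits, as the limit of > 250000 nM in this assay, at which 2 of the 3 values shown sit, records. The step of an at least 5.9-fold lower number from compound 1 to compound 2 (0.77 log units; beyond the scatter) came with trifluoromethyl in place of hydrogen on an aromatic carbon, and the step of an at least 5.9-fold higher number from compound 2 to compound 3 (0.77 log units; beyond the scatter) with methyl in place of hydrogen on a saturated chain carbon bound to a sulfonyl sulfur. Compound 4 `CS(=O)(=O)Nc1ccc(NC(=O)c2cc(C(F)(F)F)cc(C(F)(F)F)c2)cc1Cl` differs from compound 2 by chloro in place of methoxy on an aromatic carbon. Neither measured step touches the methoxy group or the chloro that replaces it, so neither bears directly on this change; both only show that one small alteration can move the result beyond the scatter in either direction. With no closer guide, compound 4 is expected to land near the value of its parent, with the step of a 1.4-fold higher number from compound 2 to compound 4 (0.15 log units; within the scatter) as the estimate, and with a wide range since the limit of > 250000 nM in this assay, at which 2 of the 3 values shown sit, shows two of the three results sitting at the limit. Compound 4 is therefore estimated at 60000 nM, between 20000 nM and 250000 nM.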

Compound 4, half-maximal inhibitory concentration: 185000 nM
Beside the measured number, compound 4's estimate is 3.1-fold (0.49 log units) below it; the measured number falls inside the stated range.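

Chloro in place of methoxy, ortho to a methanesulfonamido group, gives a 4.4-fold higher number from compound 2 to compound 4 (0.64 log units; beyond the scatter) in this assay, so on this read-out the swap means weaker inhibition, and a modest one. Going by these compounds alone, the earlier steps involved only a trifluoromethyl group and the chain on the sulfonyl sulfur, so this is the first sign that the group at this ring position also matters for the result on these cells. Compound 4 nevertheless keeps a true number rather than a limit, which matters in a small series where the results gather at the top of the measurable range: the limit of > 250000 nM in this assay, at which 2 of the 4 values shown sit.

With only methoxy and chloro at this position, the compounds shown cannot separate the effect of losing the methoxy from that of gaining the chloro, and an ethoxy, a fluoro or an amine in the same place would help to tell these apart. Within the data shown here, they also give no reason for the shift, and they leave open whether the same swap would act alike with the single trifluoromethyl of compound 1 or the longer sulfonyl chain of compound 3.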